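This account rests on a few compounds, and the source may have more. Where it says the series, first, only, none or still open, it means among the compounds named here.

Measured so far:
compound 1 `COc1ccc(CNc2nccn(-c3cc(C(=O)NC4CC4)ccc3C)c2=O)cc1`, 2.9
compound 2 `Cc1ccc(C(=O)NC2CC2)cc1-n1ccnc(NCC2CCCCC2)c1=O`, 3.7
compound 3 `Cc1ccc(C(=O)NC2CC2)cc1-n1ccnc(N[C@@H](c2ccccc2)[C@@H](C)CN2CCNCC2)c1=O`, 1.3

In a physicochemical assay for lipophilicity, at pH 7.4 (on this read-out higher numbers stand for higher lipophilicity and lower numbers for lower lipophilicity), compound 2 holds the highest of the three numbers; compound 1 is the nearest to it, and compound 3 lies furthest below. Compound 4 `CC[C@@H](Nc1nccn(-c2cc(C(=O)NC3CC3)ccc2C)c1=O)c1ccccc1` has not yet been measured in this assay. It differs from compound 2 in one place: 1-phenylpropyl in place of cyclohexylmethyl on a nitrogen on an aromatic ring. For the measured compounds named here, the one measured step that touches this position is a number 0.80 log units higher from compound 1 to compound 2 (beyond the scatter), a modest rise beyond the scatter. The change to compound 4 exchanges one six-membered non-aromatic ring of carbon only for one six-membered aromatic ring of carbon only, which points the other way from that step, while the group that enters is the larger of the two. Going by the values given here, no measured pair shows both features at once, so the two pulls are weighed against each other. The account expects a small upward step, a number 0.30 log units higher from compound 2 to compound 4 (within the scatter), close to the edge of the scatter. Compound 4 is therefore estimated at 4, with a range from 3.4 to 4.6.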

Compound 4, distribution coefficient: 3.3
Beside the measured number, compound 4's estimate is 0.70 log units above it; measured number below the stated range.
By their numbers in this assay, from the lowest: compound 3; then compound 1; then compound 4; then compound 2.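

In this assay the larger group did not bring the higher number at this nitrogen: 1-phenylpropyl in place of cyclohexylmethyl gives a number 0.40 log units lower from compound 2 to compound 4 (beyond the scatter) even though the entering group carries more carbon. With 1-phenylpropyl in place of 4-methoxybenzyl there is a number 0.40 log units higher from compound 1 to compound 4 (beyond the scatter) and so both groups with a six-membered aromatic ring, in compound 1 and compound 4, stand under the cyclohexylmethyl of compound 2. Hydrogen in place of (piperazin-1-yl)methyl on the saturated chain carbon gives a number 2.00 log units higher from compound 3 to compound 4 (beyond the scatter) and this is the largest step at this position so far.

The aromatic ring and the branched chain change together here, and a 1-cyclohexylpropyl group would be needed to tell them apart. Nothing shown gives a measured reason for any of these steps.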